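Adding a Hydroxy Group to Two Related Cores

The source may report more compounds than this note shows. Statements on the series, on what has been measured and on what is new or still open speak of the compounds shown alone.

The study compares two pairs of compounds that share a triterpenoid acid and differ in the substitution of an aromatic six-membered ring. Compound 1 `COC1=CC(=O)[C@@]2(c3cc(=O)c4ccc(OC)cc4o3)[C@H](C[C@]3(C)[C@@H](C(=O)O)CC=C4[C@H]3CCCC4(C)C)C(C)=CC[C@H]2C1=O` and compound 2 `COC1=CC(=O)[C@@]2(c3cc(=O)c4c(O)cc(OC)cc4o3)[C@H](C[C@]3(C)[C@@H](C(=O)O)CC=C4[C@H]3CCCC4(C)C)C(C)=CC[C@H]2C1=O` form the first pair; compound 3 `COC1=CC(=O)[C@@]2(c3cc(=O)c4ccc(O)cc4o3)[C@H](CC=C(C)[C@@H]2C[C@]2(C)[C@@H](C(=O)O)CC=C3[C@H]2CCCC3(C)C)C1=O` and compound 4 `COC1=CC(=O)[C@@]2(c3cc(=O)c4c(O)cc(O)cc4o3)[C@H](CC=C(C)[C@@H]2C[C@]2(C)[C@@H](C(=O)O)CC=C3[C@H]2CCCC3(C)C)C1=O` form the second. Compound 4 has not yet been measured. How the core of compound 3 differs from the core of compound 1 is not broken down here.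

In a functional assay on HepG2 cells (Homo sapiens) for antiproliferative activity, read by sulforhodamine B assay, with a stated time of 72 h (on this read-out higher numbers stand for weaker inhibition of growth and lower numbers for stronger inhibition of growth), compound 1 reaches only the limit of the assay, > 10000 nM. Compound 2 gives 8600 nM in this assay. Between them the change is hydroxy in place of hydrogen on an aromatic carbon, and it produced an at least 1.1-fold lower number from compound 1 to compound 2 (0.06 log units; that floor lies within the scatter); the step is only a floor because compound 1 sits at the limit of > 10000 nM in this assay, at which 2 of the 3 values shown sit. Compound 3 likewise reaches only the limit of this assay, > 10000 nM.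

The change from compound 3 to compound 4 is hydroxy in place of hydrogen on an aromatic carbon. It is the same kind of change as that from compound 1 to compound 2, not the same one: in the first pair the entering hydroxy sits meta to a methoxy group, in the second pair meta to a hydroxy group.

The estimated step from compound 3 to compound 4 is an at least 1.0-fold lower number from compound 3 to compound 4 (0.02 log units; that floor lies within the scatter), set beside an at least 1.1-fold lower number from compound 1 to compound 2 (0.06 log units; that floor lies within the scatter), and it rests on compound 2 giving 8600 nM after the same kind of change. Compound 4 is therefore expected to give about 9500 nM in this assay, with an estimated range from 4000 nM to 30000 nM.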

Compound 4, concentration for 50% growth inhibition: > 10000 nM
Compound 4: no number, only a limit (the forecaster's own chance of this, stated with the estimate: 55%); middle value at least 1.0-fold (0.02 log units) away from the limit.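

In this assay compound 4 gives only a limit, > 10000 nM. The step from compound 3 to compound 4 cannot be read, because both compounds stand at a limit: the limit of > 10000 nM in this assay, at which 3 of the 4 values shown sit. The compounds shown leave open whether the entering hydroxy shifts the number at all on the core of compound 3, and how any such shift would compare with the one from compound 1 to compound 2.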